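The compounds below may be only part of what the source reports. "The series", "measured", "known", "first", "only" and "open" are said of these compounds alone.

Compound 1 `O=C(Nc1ccc(F)c(-c2nc3ncc(-c4ccc(F)c(F)c4)cc3[nH]2)c1)N1CCCC1`: > 50000 nM (a limit)
Compound 2 `O=C(Nc1ccc(F)c(-c2nc3ncc(-c4ccc(F)cc4F)cc3[nH]2)c1)N1CCCC1`: 32400 nM
Compound 3 `O=C(Nc1ccc(F)c(-c2nc3ncc(C(F)(F)F)cc3[nH]2)c1)N1CCCC1`: > 50000 nM (a limit)

In an ADME assay on HepG2 cells (Homo sapiens) for cytotoxicity, read by resazurin assay, with a stated time of 48 h (a lower number here means that less compound is needed, a higher number that more compound is needed for the effect), compound 3 gives > 50000 nM. This is a limit of the assay and not a number. It is also a common result in this small set, which shows (the limit of > 50000 nM in this assay, at which 2 of the 3 values shown sit).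

Compound 4 `O=C(Nc1ccc(F)c(-c2nc3ncc(-c4cccc(F)c4)cc3[nH]2)c1)N1CCCC1` carries 3-fluorophenyl in place of trifluoromethyl on an aromatic carbon of the shared core: 3-fluorophenyl in place of trifluoromethyl on an aromatic carbon.

Going by the values given here, three measured steps bear on this change. The nearest exchanges the same kind of groups, and it is an at least 1.5-fold higher number from compound 2 to compound 3 (0.18 log units; that floor lies within the scatter). The second is a step that the two limits leave unreadable from compound 1 to compound 3, so it gives no size to work with. The third, between two fluorinated phenyl groups, is an at least 1.5-fold lower number from compound 1 to compound 2 (0.18 log units; that floor lies within the scatter).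

Putting a fluorinated phenyl back in place of trifluoromethyl might therefore lower the number slightly, or might leave it at the limit. Neither outcome would be a step beyond the scatter. The expected step is an at least 1.1-fold lower number from compound 3 to compound 4 (0.07 log units; that floor lies within the scatter). The assay may well report only a limit again.

For compound 4 the estimated value is 42000 nM, with a range of 22000 nM to 70000 nM.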

Compound 4, half-maximal effective concentration: 28200 nM
Compound 4: the middle estimate sits 1.5-fold (0.17 log units) above what was measured; the range from low to high includes it.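

In this assay, putting 3-fluorophenyl in place of trifluoromethyl gives an at least 1.7-fold lower number from compound 3 to compound 4 (0.24 log units; that floor lies within the scatter), and taking one fluoro from the 3,4-difluorophenyl group gives an at least 1.7-fold lower number from compound 1 to compound 4 (0.24 log units; that floor lies within the scatter); neither floor clears the scatter. The step between the two compounds with real numbers is a 1.1-fold lower number from compound 2 to compound 4 (0.06 log units; within the scatter), so 3-fluorophenyl and 2,4-difluorophenyl cannot be told apart in this assay. A readable number at this position is thus no longer seen with 2,4-difluorophenyl alone, while compound 1 and compound 3 remain limits of the assay: the limit of > 50000 nM in this assay, at which 2 of the 4 values shown sit.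

How far those two limits really lie from the measured numbers cannot be read. On these data alone, it also remains open whether an unsubstituted phenyl, or an amine or a carboxylic acid at this position, would move the number beyond the scatter.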